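Swapping the aryl group on a sulfonamide nitrogen

The compounds below may be only part of what the source reports. "The series", "measured", "known", "first", "only" and "open" are said of these compounds alone.

Compound 1 `Cc1ccc(NS(=O)(=O)c2ccc(N3CCNC3=O)cc2)cc1C` is measured in a functional assay on MCF7 cells (Homo sapiens) for antiproliferative activity, read by sulforhodamine B assay, with a stated time of 48 h (a lower number here means a stronger inhibitor, a higher number a weaker inhibitor), where compound 1 gives 230 nM. Compound 2 `O=C1NCCN1c1ccc(S(=O)(=O)Nc2ccc3c(c2)CCC3)cc1` gives 240 nM in this assay, and the two values sit within the scatter of each other, so neither can be called the stronger inhibitor. Compound 3 `Cc1ccccc1NS(=O)(=O)c1ccc(N2CCNC2=O)cc1` differs from compound 1 in one place: 2-methylphenyl in place of 3,4-dimethylphenyl on a sulfonamide nitrogen. Going by the values given here, no measured pair shows what such a swap does, so only a modest step is expected, if any, and more likely toward a weaker inhibitor: the expected step is a 2.0-fold higher number from compound 1 to compound 3 (0.29 log units; within the scatter). Compound 3 is therefore estimated at 450 nM, within a range from 150 nM to 1500 nM.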

Compound 3, half-maximal inhibitory concentration: 280 nM
Beside the measured number, compound 3's estimate is 1.6-fold (0.21 log units) above it, within the range that was stated.
By their numbers in this assay, from the lowest: compounds 1, 2 and 3 (each within the scatter of the next).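

In this assay, putting 2-methylphenyl in place of 3,4-dimethylphenyl on the sulfonamide nitrogen gives a 1.2-fold higher number from compound 1 to compound 3 (0.09 log units; within the scatter) and so no difference that can be told from scatter. This first one-place comparison shows that this position accepts a group with one carbon fewer without a readable change in the number. Nothing available explains this result. The compounds shown leave open whether an aryl group is needed here at all, and whether a ring carrying an amine or a carboxylic acid, or a longer alkyl chain, would shift the number beyond the scatter.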